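Hydrazide aryl group exchange at the adenine position

The compounds below may be only part of what the source reports. "The series", "measured", "known", "first", "only" and "open" are said of these compounds alone.

Measured so far:
compound 1 `CCNC(=O)[C@H]1O[C@@H](n2cnc3c(NNC(=O)c4ccco4)nc(Cl)nc32)[C@H](O)[C@@H]1O`, > 5000 nM
compound 2 `CCNC(=O)[C@H]1O[C@@H](n2cnc3c(NNC(=O)c4sccc4C)nc(Cl)nc32)[C@H](O)[C@@H]1O`, > 5000 nM
compound 3 `CCNC(=O)[C@H]1O[C@@H](n2cnc3c(NNC(=O)c4ccc[nH]4)nc(Cl)nc32)[C@H](O)[C@@H]1O`, > 5000 nM

In an assay on CHO cells for displacement of a labelled ligand from adenosine receptor A3 (Homo sapiens) (on this read-out lower numbers stand for stronger inhibition and higher numbers for weaker inhibition), compound 1 reaches only a limit of the assay, > 5000 nM. Compound 2 likewise gives a limit in this assay, > 5000 nM. Compound 3 also sits at a limit in this assay, > 5000 nM. All three values are limits; this is summarised as the limit of > 5000 nM in this assay, at which 3 of the 3 values shown sit. Accordingly the steps a step that the two limits leave unreadable from compound 1 to compound 2, a step that the two limits leave unreadable from compound 1 to compound 3 and a step that the two limits leave unreadable from compound 2 to compound 3 have no readable size, and compound 3 stands nowhere more precise than at the limit shared by the series.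

Compound 4 `CCNC(=O)[C@H]1O[C@@H](n2cnc3c(NNC(=O)c4cc(-c5ccccc5)on4)nc(Cl)nc32)[C@H](O)[C@@H]1O` differs from compound 3 by 5-phenyl-1,2-oxazol-3-yl in place of 1H-pyrrol-2-yl on a carbonyl carbon. Among the measured compounds shown here, no measured step bears on this change with a readable size, since every exchange of the aryl group on the carbonyl carbon so far has left the value at the limit. The expectation for a step that the limit leaves unreadable from compound 3 to compound 4 is therefore no readable shift, with the value of compound 4 most likely remaining a limit. Compound 4 is estimated at 8000 nM, with a range from 1500 nM to 40000 nM.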

Compound 4, inhibition constant: > 5000 nM
Compound 4 ended at the assay's limit; the forecaster's own chance of this, stated with the estimate: 70%; the middle value lies beyond the limit too.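

In this assay compound 4 gives > 5000 nM, which is a limit. Its steps from compound 1, compound 2 and compound 3 therefore cannot be read, and the series shares a single result: the limit of > 5000 nM in this assay, at which 4 of the 4 values shown sit.

The compounds shown leave open how far each of these aryl groups on the carbonyl carbon lies beyond that limit, and whether they differ at all.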